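The source may hold more compounds than are shown below. What is called first, only, known or untested is meant among the compounds shown, and "the series" means these compounds.

Working notes on the series. For the measured compounds named here, in an ADME assay on L6 cells (Rattus norvegicus) for cytotoxicity, read by resazurin assay, with a stated time of 70 h (on this read-out lower numbers stand for stronger inhibition and higher numbers for weaker inhibition), compound 2 `CC(=O)Oc1ccc2c(c1)C(C)=CC(C)(C)N2Cc1ccccc1` gives 24000 nM and compound 3 `CC(=O)Oc1ccc2c(c1)C(C)=CC(C)(C)N2Cc1ccc(C)cc1` gives 21000 nM as the only two numbers so far, and these two sit within the scatter of each other. In this assay compound 1 `CC1=CC(C)(C)N(Cc2ccc(C(F)(F)F)cc2)c2ccc(OCc3ccc(C(F)(F)F)cc3)cc21` returns only a limit (> 180000 nM) and no number.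

Compound 4 `CC(=O)Oc1ccc2c(c1)C(C)=CC(C)(C)N2Cc1ccc(C(F)(F)F)cc1` differs from compound 3 by trifluoromethyl in place of methyl on an aromatic carbon, para to a large group (trifluoromethyl in place of methyl on an aromatic carbon). Going by the values given here, the one measured step of a similar kind is methyl in place of hydrogen on an aromatic carbon (a 1.1-fold lower number from compound 2 to compound 3 (0.06 log units; within the scatter)), and it stays within the scatter. Among the compounds with values here, compound 1 is joined to the others by no single-place step, so its limit sets no size for this change. A single small step is thin support, so the range is kept wide, but no shift beyond the scatter is expected in this assay here. The expected size is a 1.2-fold higher number from compound 3 to compound 4 (0.08 log units; within the scatter) and no more. Compound 4 is estimated at 25000 nM with an expected range from 10000 nM to 70000 nM in this read-out.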

Compound 4, half-maximal inhibitory concentration: 14000 nM
Compound 4: middle estimate off by 1.8-fold (0.25 log units), on the high side; measured number inside the range.
By their numbers in this assay, from the lowest: compounds 4, 3 and 2 (each within the scatter of the next). At a limit, above all of these: compound 1.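

In this assay, trifluoromethyl on this aromatic carbon, para to a large group, stays within the scatter whether it replaces methyl, a 1.5-fold lower number from compound 3 to compound 4 (0.18 log units; within the scatter), or hydrogen, a 1.7-fold lower number from compound 2 to compound 4 (0.23 log units; within the scatter). Across the methyl, trifluoromethyl and hydrogen compounds, this position therefore shows no change that can be told from the scatter, while the only step beyond it lies at the oxygen on an aromatic ring, with acetyl in place of 4-(trifluoromethyl)benzyl, an at least 12-fold lower number from compound 1 to compound 4 (1.10 log units; beyond the scatter). That step ends on a limit for compound 1, not on a number: the limit of > 180000 nM in this assay, at which 1 of the 4 values shown sits.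

From the compounds shown here alone, whether an amine or a carboxylic acid on the same aromatic carbon would move the read-out beyond the scatter remains open. Also open, going by these compounds, is how a free hydroxyl or a longer acyl chain on the oxygen would read against acetyl.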